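Phenyl Substitution on Two Spirocyclic Thiophene Cores

A few compounds are considered here, and "the series" means these few. Any claim that something is new, unique, unknown or untested is made for them only; others in the source may bear on it.

Measured compounds:
compound 1, `O=C1Cc2cscc2C2(CCN(Cc3ccccc3)CC2)O1`: 40 nM
compound 2, `O=C1Cc2c(csc2-c2ccccc2)C2(CCN(Cc3ccccc3)CC2)O1`: 2.5 nM
compound 3, `O=C1OC2(CCN(Cc3ccccc3)CC2)c2c1csc2-c1ccccc1`: 483 nM

In an assay on membranes from brain for displacement of a labelled ligand from Sigma non-opioid intracellular receptor 1 (Cavia porcellus), read by scintillation counting, with a stated time of 120 min (on this read-out lower numbers stand for stronger inhibition and higher numbers for weaker inhibition), compound 1 gives 40 nM, whereas compound 2 gives 2.5 nM. The change between them, (phenyl in place of hydrogen on an aromatic carbon), made the step of a 16-fold lower number from compound 1 to compound 2 (1.20 log units; beyond the scatter). Compound 3 gives 483 nM, the highest number of the three. The difference between the core of compound 1 and the core of compound 3 is not broken down here.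

Compound 4, `O=C1OC2(CCN(Cc3ccccc3)CC2)c2c(-c3ccccc3)sc(-c3ccccc3)c21`, has not yet been measured in this assay. It arises from compound 3 by phenyl in place of hydrogen on an aromatic carbon, the same kind of change as that from compound 1 to compound 2, though the place differs: here it also lies two ring bonds from the ring atom that bears a phenyl group. The step from compound 3 to compound 4 is expected to be a 4.8-fold lower number from compound 3 to compound 4 (0.68 log units; beyond the scatter), smaller than the earlier one, because a 16-fold lower number from compound 1 to compound 2 (1.20 log units; beyond the scatter) was made on a different core and compound 3 starts from 483 nM. Compound 4 is therefore estimated at 100 nM, with a likely range from 25 nM to 400 nM.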

Compound 4, inhibition constant: 87 nM
Compound 4: the middle estimate sits 1.1-fold (0.06 log units) above what was measured; low and high end bracket the measured number.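

In this assay, phenyl in place of hydrogen on an aromatic carbon gave a 5.6-fold lower number from compound 3 to compound 4 (0.74 log units; beyond the scatter), so the direction of the earlier step held on a second core. The size of the step did not hold: the same change on two cores in this assay, a 16-fold lower number (1.20 log units; beyond the scatter) from compound 1 to compound 2 and a 5.6-fold lower number (0.74 log units; beyond the scatter) from compound 3 to compound 4, 2.9-fold (0.46 log units) apart, beyond the scatter of two such steps The two steps differ both in the core and in the place of the phenyl, which here lies two ring bonds from the ring atom that bears a phenyl group, and this pair does not separate those two differences or show how the change would behave on any further core.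

The compounds shown leave open whether a methyl group or an amine on the same aromatic carbon, next to the ring sulfur, would lower the number as phenyl does. They also leave open how a longer chain in place of the benzyl group would behave on either core.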